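The compounds below may be only part of what the source reports. "The series", "measured", "known", "first", "only" and "open" are said of these compounds alone.

Measured compounds:
- compound 1 `COC(=O)N1C[C@H](NC(=O)OCCCCC2CCCCC2)C1=O`: 7180 nM
- compound 2 `CON1C[C@H](NC(=O)OCCCCC2CCCCC2)C1=O`: 16 nM
- compound 3 `CCCCCON1C(=O)[C@@H](NC(=O)OCCCCC2CCCCC2)[C@@H]1C`: 387 nM

In an assay on HEK293 cells for inhibition of N-acylethanolamine-hydrolyzing acid amidase (Homo sapiens), read by fluorescence, with stated times of 10 min and 50 min (on this read-out higher numbers stand for weaker inhibition and lower numbers for stronger inhibition), compound 3 stands second highest of the three numbers: compound 1 gives a higher number, compound 2 a lower one. Within the data shown here, the only single-point step so far, a 450-fold lower number from compound 1 to compound 2 (2.65 log units; beyond the scatter), concerns the group on the ring nitrogen and not the chain attached to it. Compound 4 `C[C@H]1[C@H](NC(=O)OCCCCC2CCCCC2)C(=O)N1OCCCS(C)(=O)=O` differs from compound 3 by methylsulfonyl in place of ethyl on a saturated chain carbon, three bonds along the chain from an oxygen on an unsaturated carbon. Among the measured compounds shown here, no measured step touches this chain end, so nothing here points to a change in either direction, and the step from compound 3 to compound 4 is expected to be a 1.3-fold higher number from compound 3 to compound 4 (0.11 log units; within the scatter), close to the scatter. Compound 4 is therefore estimated at 500 nM in this assay, with a range from 150 nM to 1700 nM.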

Compound 4, half-maximal inhibitory concentration: 49 nM
Compound 4: middle estimate off by 10-fold (1.01 log units), on the high side, outside the stated range (below it).
By their numbers in this assay, from the lowest: compound 2; then compound 4; then compound 3; then compound 1.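

Putting methylsulfonyl in place of ethyl at this chain end gives a 7.9-fold lower number from compound 3 to compound 4 (0.90 log units; beyond the scatter) in this assay, so the far end of this chain also affects the result. Among these compounds, the only earlier step concerned the group on the ring nitrogen and did not reach this chain end. Methylsulfonyl brings two hydrogen-bond acceptors where ethyl has none, but nothing available explains why the number falls. From the compounds shown here alone, it remains open whether an amine, a carboxylic acid or a longer chain at this place would shift the number in the same direction.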